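The source may hold more compounds than are shown below. What is called first, only, known or untested is meant among the compounds shown, and "the series" means these compounds.

Compound 1 `Cc1nn(-c2nc(-c3ccc(Cl)c(Cl)c3)c(SC(C)C)s2)c(C(=O)O)c1-c1cccc(C(F)(F)F)c1` is the point of departure. In a functional assay on BJAB cells (Homo sapiens) for antiproliferative activity, with a stated time of 4 days (a higher number here means that more compound is needed for the effect, a lower number that less compound is needed), compound 1 gives 22000 nM, the second highest of three numbers. Compound 3 `CCSc1sc(-n2nc(C)c(Cc3ccccc3[N+](=O)[O-])c2C(=O)OC)nc1-c1ccc(Cl)c(Cl)c1` gives 106000 nM in this assay. Compound 2 `Cc1nn(-c2nc(-c3ccc(Cl)c(Cl)c3)c(SC(C)C)s2)c(C(=O)O)c1-c1cc(C(F)(F)F)cc(C(F)(F)F)c1` gives 1800 nM in this assay, and a 12-fold lower number from compound 1 to compound 2 (1.09 log units; beyond the scatter) shows that altering the ring on this side of the shared core moves the number strongly. Compound 4 `CCOc1ncccc1-c1c(C)nn(-c2nc(-c3ccc(Cl)c(Cl)c3)c(SC(C)C)s2)c1C(=O)O` is the new compound; (2-ethoxypyridin-3-yl in place of 3-(trifluoromethyl)phenyl on an aromatic carbon). For the measured compounds named here, no measured step exchanges the whole ring, only a group on it, so the direction is open. The expectation for compound 4 is therefore a number close to compound 1, about 20000 nM with a wide range from 4000 nM to 100000 nM, meaning a 1.1-fold lower number from compound 1 to compound 4 (0.04 log units; within the scatter).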

Compound 4, half-maximal effective concentration: 11000 nM
For compound 4 the middle estimate is 1.8-fold (0.26 log units) above the measured one; low and high end bracket the measured number.
By their numbers in this assay, from the lowest: compound 2; then compounds 4 and 1 (each within the scatter of the next); then compound 3.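

In this assay, the whole ring at this position can be exchanged: 2-ethoxypyridin-3-yl in place of 3-(trifluoromethyl)phenyl gives a 2.0-fold lower number from compound 1 to compound 4 (0.30 log units; within the scatter), so the number stays within the usual scatter. The earlier step changed only a group on the ring, whereas this one shows that a ring of carbon only is not required here. Nothing measured here explains this outcome. Open, as far as these compounds go, is whether the ethoxy group or the ring nitrogen matters more, since both enter together, and whether an amine or a longer chain such as butoxy in place of ethoxy would move the number.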